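The compounds below may be only part of what the source reports. "The series", "measured", "known", "first", "only" and "open" are said of these compounds alone.

In an in vitro assay on Sf9 cells for inhibition of 17-beta-hydroxysteroid dehydrogenase type 1 (Homo sapiens), tested at 100 nM (a lower number here means a weaker effect, a higher number a stronger effect of the compound at the concentration tested), compound 1 `O=C(c1c(O)ccc2cc(-c3cccc(O)c3)ccc12)N1CCOCC1` gives 28%. Compound 2 `Cc1nnc(NC(=O)c2c(O)ccc3cc(-c4cccc(O)c4)ccc23)s1` shares the same core as compound 1, but in this assay compound 2 gives "not determined" (no result reported), so it stands without a number. Compound 3 `CNC(=O)c1c(O)ccc2cc(-c3cccc(O)c3)ccc12` differs from compound 2 in one place: methyl in place of 5-methyl-1,3,4-thiadiazol-2-yl on an amide-type nitrogen. Among the measured compounds shown here, because compound 2 has no measurement, no step from compound 2 to compound 3 can be given, and the shift in this assay is expected to stay within the usual scatter, with no clear direction. Compound 3 is expected to give about 30% in this assay, within a range from 8% to 55%.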

Compound 3, a percentage reported as inhibition, at one concentration (the size of the read-out at that concentration, not a potency): 22%
For compound 3 the middle estimate is 8 percentage points above the measured one; low and high end bracket the measured number.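

In this assay, the swap on the carbonyl carbon shows a number 6 percentage points lower from compound 1 to compound 3 (within the scatter), so the morpholin-4-yl ring and the much smaller methylamino cannot be told apart here. Compound 2 carries no number, so its step to compound 3 cannot be read. No available measurement explains this result.

Going by these compounds, what a longer chain such as butylamino, or a benzylamino group, would do on the same carbonyl carbon stays open. So does whether the 5-methyl-1,3,4-thiadiazol-2-yl group differs from methyl on the amide-type nitrogen.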